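The compounds below may be only part of what the source reports. "The series", "measured", "known", "first", "only" and "open" are said of these compounds alone.

Compound 3 `Cn1cc(-c2cnc(N)c(Oc3ccc(C(=O)Nc4cccc(Cl)c4)cc3)n2)cn1` carries a 1-methyl-1H-pyrazol-4-yl group on its core and a 3-chlorophenyl amide at the other end. In a functional assay on LoVo cells (Homo sapiens) for inhibition, read by MTT assay, with a stated time of 72 h (a higher number here means a weaker inhibitor, a lower number a stronger inhibitor), compound 3 gives 24500 nM, the highest number of the three measured compounds. Its nearest neighbour is compound 2 `Cn1cc(-c2cnc(N)c(Oc3ccc(C(=O)Nc4ccccc4)cc3)n2)cn1`, which in this assay gives 9210 nM; the step of a 2.7-fold higher number from compound 2 to compound 3 (0.42 log units; beyond the scatter) is modest. Compound 1 `Cc1noc(C)c1-c1cnc(N)c(Oc2ccc(C(=O)Nc3cccc(Cl)c3)cc2)n1`, which in this assay gives 1640 nM, lies furthest away, and the step of a 15-fold higher number from compound 1 to compound 3 (1.17 log units; beyond the scatter) is large. Compound 3 is therefore the weakest inhibitor among the three.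

Compound 4 `Cn1cc(-c2cnc(N)c(Oc3ccc(C(=O)Nc4cc(Cl)ccn4)cc3)n2)cn1` differs from compound 3 by 4-chloropyridin-2-yl in place of 3-chlorophenyl on an amide-type nitrogen. Neither measured step bears directly on this exchange: the step from compound 1 to compound 3 concerns the group on the core, and the step from compound 2 to compound 3 concerns a chloro substituent, while compound 4 keeps the chlorine and changes the ring itself. Within the data shown here, with no comparable step measured, the expectation for this assay is no step beyond the scatter, as a 1.2-fold lower number from compound 3 to compound 4 (0.09 log units; within the scatter) expresses. Compound 4 is estimated to give 20000 nM in this assay, with a range from 6000 nM to 60000 nM.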

Compound 4, half-maximal inhibitory concentration: 26600 nM
Compound 4: middle estimate off by 1.3-fold (0.12 log units), on the low side; low and high end bracket the measured number.
By their numbers in this assay, from the lowest: compound 1; then compound 2; then compounds 3 and 4 (each within the scatter of the next).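

In this assay the amide-type nitrogen tolerates an exchange of the ring itself: 4-chloropyridin-2-yl in place of 3-chlorophenyl, which adds a ring nitrogen and a hydrogen-bond acceptor, gives a 1.1-fold higher number from compound 3 to compound 4 (0.04 log units; within the scatter) and so no step beyond the scatter. Measured against the unsubstituted phenyl of compound 2, the same new group gives a 2.9-fold higher number from compound 2 to compound 4 (0.46 log units; beyond the scatter) and thus lies on the same side of compound 2 as the 3-chlorophenyl of compound 3, so with 1-methyl-1H-pyrazol-4-yl on the core both chlorine-bearing rings give higher numbers than phenyl. No measured property of these groups is available to account for either step.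

The compounds shown pair the 4-chloropyridin-2-yl amide only with 1-methyl-1H-pyrazol-4-yl, which leaves open whether it would behave alike with the 3,5-dimethyl-1,2-oxazol-4-yl group of compound 1, which gives 1640 nM in this assay. Also open, going by these compounds, is what a ring carrying an amine or a carboxylic acid in place of the chlorine would give on this amide-type nitrogen.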